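Methoxy Added to a Stilbene-like Core: Two Series Compared

The compounds below may be only part of what the source reports. "The series", "measured", "known", "first", "only" and "open" are said of these compounds alone.

The measured compounds, in a functional assay on MCF7 cells (Homo sapiens) for cytotoxicity, read by MTT assay, with a stated time of 72 h; a higher number here means a weaker inhibitor, a lower number a stronger inhibitor:
Compound 1, `COc1ccc(/C=C/c2cc(C)n[nH]2)cc1`, gives 9700 nM.
Compound 2, `COc1ccc(/C=C/c2cc(C)n[nH]2)cc1OC`, gives 12600 nM.
Compound 3, `Cc1cc(/C=C/c2ccc(O)cc2)on1`, gives 50200 nM.

Compounds 1 and 2 share one core, and compound 3 has another; the difference between the two cores is not broken down here. Compounds 1 and 2 differ in one place: methoxy in place of hydrogen on an aromatic carbon. This gave a 1.3-fold higher number from compound 1 to compound 2 (0.11 log units; within the scatter), so in this assay the two are not told apart. Compound 3 stands apart from both in this assay with the highest number of the three.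

Compound 4, `COc1cc(/C=C/c2cc(C)no2)ccc1O`, has not yet been measured. It differs from compound 3 in the same kind of change: methoxy in place of hydrogen on an aromatic carbon. The surroundings are not identical, since in compound 2 the new methoxy sits ortho to a methoxy group, whereas in compound 4 it sits ortho to a hydroxy group. Because a 1.3-fold higher number from compound 1 to compound 2 (0.11 log units; within the scatter) was within the scatter, the expected step is a 1.1-fold higher number from compound 3 to compound 4 (0.04 log units; within the scatter), close to no change. The estimate for compound 4 in this assay is 55000 nM, with a range from 25000 nM to 120000 nM.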

Compound 4, half-maximal inhibitory concentration: 20900 nM
Beside the measured number, compound 4's estimate is 2.6-fold (0.42 log units) above it; the measured number lies below the stated range.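

In this assay the methoxy on the core of compound 3 gave a 2.4-fold lower number from compound 3 to compound 4 (0.38 log units; beyond the scatter) and so made compound 4 the stronger inhibitor of that pair. The same swap of hydrogen for methoxy did not carry over unchanged from one core to the other: the same change on two cores in this assay, a 1.3-fold higher number (0.11 log units; within the scatter) from compound 1 to compound 2 and a 2.4-fold lower number (0.38 log units; beyond the scatter) from compound 3 to compound 4, 3.1-fold (0.49 log units) apart, beyond the scatter of two such steps. For the compounds shown here, a step read on one core was therefore a poor guide to the other here, but with only one pair per core this does not show why, since the pairs differ both in their cores and in their surroundings, the new methoxy in compound 4 sitting ortho to a hydroxy group.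

The compounds shown leave open whether the lower number of compound 4 depends on that hydroxy group, which a matching pair carrying the same methoxy without it could test. They also leave open whether another group on the same carbon, such as an ethoxy group or an amine, would lower the number further on the core of compound 3.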